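From a chloro limit back to hydrogen

The source may hold more compounds than are shown below. What is called first, only, known or untested is meant among the compounds shown, and "the series" means these compounds.

In a functional assay on MCF7 cells (Homo sapiens) for inhibition, in the presence of a further agent that is not named here (a lower number here means a stronger inhibitor, a higher number a weaker inhibitor), compound 1 `Nc1ccc(-c2cc(=O)c3c(N)ccc(F)c3o2)cc1` gives 170 nM, and compound 2 `Nc1ccc(-c2cc(=O)c3c(N)c(F)ccc3o2)cc1` gives 130 nM. Compound 3 `Nc1ccc(-c2cc(=O)c3c(N)c(Cl)ccc3o2)cc1` gives > 10000 nM, which is a limit of the assay and not a number. It stands at the limit of > 10000 nM in this assay, at which 1 of the 3 values shown sits.

Compound 4 `Nc1ccc(-c2cc(=O)c3c(N)cccc3o2)cc1` has not yet been measured. It differs from compound 3 by hydrogen in place of chloro on an aromatic carbon, ortho to an amino group.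

Two measurements bear on this change. Within the data shown here, the first is the large step for chloro in place of fluoro on this carbon, an at least 76-fold higher number from compound 2 to compound 3 (1.88 log units; beyond the scatter). The second is compound 1, which also carries hydrogen on this carbon and gives 170 nM.

A large step towards a stronger inhibitor is therefore expected in this assay, bringing the number back to the range of the two measured compounds. The expected change is an at least 120-fold lower number from compound 3 to compound 4 (2.09 log units; beyond the scatter). Compound 4 is estimated at 80 nM, with an expected range of 8 nM to 800 nM.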

Compound 4, half-maximal inhibitory concentration: 210 nM
Beside the measured number, compound 4's estimate is 2.6-fold (0.42 log units) below it, and the stated range covers the measured number.
By their numbers in this assay, from the lowest: compounds 2, 1 and 4 (each within the scatter of the next). At a limit, above all of these: compound 3.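

In this assay, hydrogen in place of chloro on the aromatic carbon ortho to an amino group gives an at least 47-fold lower number from compound 3 to compound 4 (1.67 log units; beyond the scatter), so the weak result at this position goes with chloro and not with the core itself. That step rests on a limit for compound 3 and not on a number: the limit of > 10000 nM in this assay, at which 1 of the 4 values shown sits. Fluoro and hydrogen on this carbon are not told apart, with a 1.6-fold higher number from compound 2 to compound 4 (0.21 log units; within the scatter), and fluoro at a different place on the core is not told apart from hydrogen either, with a 1.2-fold higher number from compound 1 to compound 4 (0.09 log units; within the scatter).

The compounds shown leave open whether a bromo, methyl or methoxy group on this carbon would go with chloro or with fluoro and hydrogen. They also leave open what chloro does at the carbon where compound 1 carries fluoro.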